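The compounds below may be only part of what the source reports. "The series", "measured", "known", "first", "only" and "open" are said of these compounds alone.

In a functional assay on CWR22R cells (Homo sapiens) for antiproliferative activity, read by propidium iodide staining, with a stated time of 96 h (a higher number here means a weaker inhibitor, a lower number a stronger inhibitor), compound 1 (`CC(O)(CS(=O)(=O)c1ccc(S(F)(F)(F)(F)F)cc1)C(=O)Nc1cccc(S(F)(F)(F)(F)F)c1`) gives 12300 nM and compound 2 (`CC(O)(CS(=O)(=O)c1ccc(F)cc1)C(=O)Nc1cccc(S(F)(F)(F)(F)F)c1`) gives 38900 nM while compound 3 (`CC(O)(CS(=O)(=O)c1cccc(C(F)(F)F)c1)C(=O)Nc1cccc(S(F)(F)(F)(F)F)c1`) gives 24600 nM on the same read-out. Compound 3 therefore lies within the scatter of each of the other two, although those two differ from each other by more than the scatter. The next compound, compound 4 (`CC(O)(CS(=O)(=O)c1ccc(OC(F)(F)F)cc1)C(=O)Nc1cccc(S(F)(F)(F)(F)F)c1`), carries 4-(trifluoromethoxy)phenyl in place of 3-(trifluoromethyl)phenyl on a sulfonyl sulfur and keeps the rest of the structure of compound 3. Among the compounds with values here, two measured steps bear on this change. At the same sulfonyl sulfur, 3-(trifluoromethyl)phenyl in place of 4-fluorophenyl gave a 1.6-fold lower number from compound 2 to compound 3 (0.20 log units; within the scatter) and so changed little that can be told from the scatter. On the aromatic carbon of the sulfonyl-bound ring, one fluorine atom in place of a group of 6 heavy atoms gave a 3.2-fold higher number from compound 1 to compound 2 (0.50 log units; beyond the scatter) as a modest step. Within the data shown here, neither step tests trifluoromethoxy directly, and the data hold no compound that carries it. No step beyond the scatter is therefore expected in this assay in either direction. For compound 4 the expected change is a 1.2-fold lower number from compound 3 to compound 4 (0.09 log units; within the scatter) as a small move within the scatter. Compound 4 is estimated at 20000 nM with an expected range from 9000 nM to 42000 nM in this measurement.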

Compound 4, half-maximal inhibitory concentration: 31200 nM
Estimate against measurement, compound 4: 1.6-fold (0.19 log units) below; the measured number falls inside the stated range.
By their numbers in this assay, from the lowest: compounds 1, 3, 4 and 2 (each within the scatter of the next, the first and the last beyond it).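

In this assay, moving from 3-(trifluoromethyl)phenyl to 4-(trifluoromethoxy)phenyl on the sulfonyl sulfur gives a 1.3-fold higher number from compound 3 to compound 4 (0.10 log units; within the scatter), so these two groups cannot be told apart here. Trifluoromethoxy, the first group of its kind at this place, also cannot be told apart from fluoro on the aromatic carbon, with a 1.2-fold lower number from compound 2 to compound 4 (0.10 log units; within the scatter). Only the comparison with the group of 5 fluorine and 1 sulfur in compound 1 clears the scatter, with a 2.5-fold higher number from compound 1 to compound 4 (0.40 log units; beyond the scatter), which joins a 3.2-fold higher number from compound 1 to compound 2 (0.50 log units; beyond the scatter) as a second replacement of that group to do so, although compound 3 goes against any clean separation of compound 1 from the rest, since it stays within the scatter of compound 1.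

Nothing shown explains why these numbers fall as they do. The compounds shown leave open how an amine or a carboxylic acid in place of trifluoromethoxy on that aromatic carbon would read in this assay, and whether any replacement on the sulfonyl sulfur can give a number clearly lower than that of compound 1.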